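This account rests on a few compounds, and the source may have more. Where it says the series, first, only, none or still open, it means among the compounds named here.

Compound 1, `CCOC(=O)c1c(-c2cccc(-c3ccccc3)c2)[nH]c2cc(OC(C)C)ccc2c1=O`, gives > 21500 nM in an ADME assay on HepG2 cells (Homo sapiens) for cytotoxicity, read by luminescence, with a stated time of 72 h; on this read-out lower numbers stand for an effect already at smaller amounts and higher numbers for an effect only at larger amounts of compound; this is a limit of the assay, not a number.
Compound 2, `CCOC(=O)c1c(-c2cccc(OC)c2)[nH]c2cc(OC(C)C)ccc2c1=O`, gives > 21500 nM in this assay; this value is also a limit.
Compound 3, `CCOC(=O)c1c(-c2cccc(-c3ccccc3)c2)[nH]c2cc(OC)c(OC)cc2c1=O`, gives > 21500 nM in this assay; this too is a limit.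

All three measured compounds therefore sit at the same boundary of this assay, as summed up in the limit of > 21500 nM in this assay, at which 3 of the 3 values shown sit. The change from compound 1 to compound 2 is methoxy in place of phenyl on an aromatic carbon, and the step it produced is a step that the two limits leave unreadable from compound 1 to compound 2, because both ends of the pair rest on (the limit of > 21500 nM in this assay, at which 3 of the 3 values shown sit). How the core of compound 1 and the core of compound 3 differ is not broken down here.

Compound 4, `CCOC(=O)c1c(-c2cccc(OC)c2)[nH]c2cc(OC)c(OC)cc2c1=O`, has not yet been measured in this assay. It differs from compound 3 by methoxy in place of phenyl on an aromatic carbon, which is the same change that was made from compound 1 to compound 2, at the same place.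

Since the change from compound 1 to compound 2 left the reading at the limit, and compound 3 is itself at that limit, compound 4 is expected to show a step that the limit leaves unreadable from compound 3 to compound 4, which in practice means another limit reading is the most likely outcome. The estimate for compound 4 in this assay is 30000 nM, with an expected range from 15000 nM to 100000 nM.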

Compound 4, half-maximal effective concentration: > 21500 nM
Compound 4 was reported as a limit; the forecaster's own chance of this, stated with the estimate: 85%; the middle value lies beyond the limit too.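

No size can be read for the change from compound 3 to compound 4, because both compounds rest on the same boundary: the limit of > 21500 nM in this assay, at which 4 of the 4 values shown sit. The compounds shown leave open whether exchanging phenyl for methoxy on this aromatic carbon, or the difference between the core of compound 1 and the core of compound 3, changes cytotoxicity at amounts beyond this limit.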